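A few compounds are considered here, and "the series" means these few. Any claim that something is new, unique, unknown or untested is made for them only; others in the source may bear on it.

Compound 1 `Nc1nc(-c2ccc(OCCO)cc2)cn2c(=O)n(-c3ccccc3)nc12`, compound 2 `Nc1nc(-c2ccc(OCCCl)cc2)cn2c(=O)n(-c3ccccc3)nc12` and compound 3 `Nc1nc(-c2ccc(OCC(O)CO)cc2)cn2c(=O)n(-c3ccccc3)nc12` share one core and differ only in the chain attached to the oxygen on the aromatic ring. In an assay on CHO cells for antagonist activity at adenosine receptor A2b (Homo sapiens) (a higher number here means a weaker inhibitor, a lower number a stronger inhibitor), compound 1 gives > 30000 nM, which is a limit of the assay and not a number. Compound 2 likewise reaches only the limit > 30000 nM. Compound 3 also stands at the limit > 30000 nM, so its place among the three cannot be ranked. The steps a step that the two limits leave unreadable from compound 1 to compound 2, a step that the two limits leave unreadable from compound 1 to compound 3 and a step that the two limits leave unreadable from compound 2 to compound 3 stay unreadable because of the limit of > 30000 nM in this assay, at which 3 of the 3 values shown sit. Compound 4 `Nc1nc(-c2ccc(OCC(O)CN3CCCCC3)cc2)cn2c(=O)n(-c3ccccc3)nc12` carries the change (piperidin-1-yl in place of hydroxy on a saturated chain carbon, two bonds along the chain from an oxygen on a saturated carbon). Going by the values given here, no measured step bears on this change, so the expected step of an at least 1.2-fold lower number from compound 3 to compound 4 (0.07 log units; that floor lies within the scatter) rests on no precedent and is estimated with wide uncertainty. Compound 4 is therefore expected near 25000 nM, somewhere between 3000 nM and 100000 nM.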

Compound 4, half-maximal inhibitory concentration: > 30000 nM
Compound 4: only a limit was reported; the forecaster's own chance of this, stated with the estimate: 60%; at least 1.2-fold (0.07 log units) between middle value and limit.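

Compound 4 also stands at a limit, so its steps to compound 1, compound 2 and compound 3 cannot be read: the limit of > 30000 nM in this assay, at which 4 of the 4 values shown sit. The compounds shown leave open how these four chains rank in this assay.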